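Putting a chain on the aromatic nitrogen of compound 3

The source may hold more compounds than are shown below. What is called first, only, known or untested is meant among the compounds shown, and "the series" means these compounds.

Values in a functional assay on ECa-109 cells (Homo sapiens) for antiproliferative activity, read by MTT assay, with a stated time of 48 h; a higher number here means a weaker inhibitor, a lower number a stronger inhibitor:
- compound 1 `Cn1cc(C2=C(c3nn(CCn4ccnc4)c4ncccc34)C(=O)N(c3ccccc3)C2=O)c2ccccc21`: 8770 nM
- compound 2 `CN1CCN(CCCn2nc(C3=C(c4cn(C)c5ccccc45)C(=O)NC3=O)c3cccnc32)CC1`: > 100000 nM, a limit
- compound 3 `Cn1cc(C2=C(c3n[nH]c4ncccc34)C(=O)NC2=O)c2ccccc21`: 46100 nM

Compound 3 has the higher of the two true numbers, and compound 1 the lower. Compound 4 `Cn1cc(C2=C(c3nn(CCCO)c4ncccc34)C(=O)NC2=O)c2ccccc21` has 3-hydroxypropyl in place of hydrogen on an aromatic nitrogen. Among the measured compounds shown here, the only measured step at that nitrogen is an at least 2.1-fold lower number from compound 2 to compound 3 (0.33 log units; beyond the scatter). Its size rests on (the limit of > 100000 nM in this assay, at which 1 of the 3 values shown sits). Read in reverse, it suggests that a chain there raises the number. Compound 1 goes against this, with 8770 nM and a substituent on that nitrogen. The expected step is a 1.2-fold higher number from compound 3 to compound 4 (0.08 log units; within the scatter), so no clear shift is expected. For compound 4 the estimate is 55000 nM, with an expected range of 20000 nM to 100000 nM.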

Compound 4, half-maximal inhibitory concentration: > 100000 nM
Compound 4 ended at the assay's limit (the forecaster's own chance of this, stated with the estimate: 30%); middle value at least 1.8-fold (0.25 log units) from the limit.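

In this assay, 3-hydroxypropyl on the aromatic nitrogen gives an at least 2.1-fold higher number from compound 3 to compound 4 (0.33 log units; beyond the scatter), so a chain ending in hydroxy raises the number, as the chain of compound 2 with its 4-methylpiperazin-1-yl end does. Compound 1, with 8770 nM, goes against this pattern, though it differs from compound 3 in more than one place. Compound 2 and compound 4 both stand at a limit, and the step between them cannot be read: the limit of > 100000 nM in this assay, at which 2 of the 4 values shown sit.

Open, as far as these compounds go, is whether a methyl group, a shorter chain or a carboxylic acid on that nitrogen would keep the number near that of compound 3. From the compounds shown here alone, how far the true values of compound 2 and compound 4 lie past the limit also stays open.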